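Removing one methoxy group from a triazole-linked anisole pair

The source may hold more compounds than are shown below. What is called first, only, known or untested is meant among the compounds shown, and "the series" means these compounds.

In a functional assay on MDA-MB-231 cells (Homo sapiens) for cytotoxicity, read by MTT assay (on this read-out higher numbers stand for weaker inhibition and lower numbers for stronger inhibition), the three measured compounds give only limits of the assay, no numbers. Compound 3 `COc1ccc(-n2cc(-c3ccc(OC)c(OC)c3)nn2)cc1` sits at > 100 nM, which is a limit. Compound 1 `COc1ccc(-c2cn(-c3ccc(Oc4ccccc4)cc3)nn2)cc1` likewise reaches only > 100 nM, a limit. Compound 2 `COc1ccc(-n2cc(-c3ccc(OC)c(O)c3)nn2)cc1` is recorded at > 10000 nM, again a limit. Within the data shown here, the one change between measured compounds, from compound 2 to compound 3 (methyl in place of hydrogen on an oxygen on an aromatic ring), gives a step that the two limits leave unreadable from compound 2 to compound 3, so its size cannot be read from the two limits. Two of the three values share (the limit of > 100 nM in this assay, at which 2 of the 3 values shown sit), and one sits at the limit of > 10000 nM in this assay, at which 1 of the 3 values shown sits.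

Compound 4 `COc1ccc(-c2cn(-c3ccc(OC)cc3)nn2)cc1` differs from compound 3 by hydrogen in place of methoxy on an aromatic carbon: the methoxy ortho to the remaining methoxy group and meta to the large group is replaced by hydrogen. No measured step matches this change, and the only step available is unreadable, so nothing shown points to a direction. Compound 4 is therefore expected to stay weak, with a step that the limit leaves unreadable from compound 3 to compound 4 as the expected step from the limit of compound 3. The estimate for compound 4 in this assay is 5000 nM, with a range from 300 nM to 50000 nM, and a further limit rather than a number is expected most often.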

Compound 4, half-maximal inhibitory concentration: > 100 nM
Compound 4: a limit, no number; the forecaster's own chance of this, stated with the estimate: 70%; the middle value is on the limit's open side.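

In this assay compound 4 gives > 100 nM, which is a limit and not a number. With limits at both ends, the steps to compound 4 from compound 1, compound 2 and compound 3 cannot be read. The compounds shown leave open how strongly any of them inhibits, and whether hydrogen in place of methoxy changes that at all.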